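The compounds below may be only part of what the source reports. "The series", "measured", "known", "first", "only" and "open" are said of these compounds alone.

Measured in a functional assay on HepG2 cells (Homo sapiens) for cytotoxicity, read by MTT assay, with a stated time of 48 h; on this read-out lower numbers stand for stronger inhibition and higher numbers for weaker inhibition:
- compound 1 `COc1ccccc1-c1nnc(SCCn2c([N+](=O)[O-])cnc2C)o1`: 10000 nM
- compound 2 `Cc1ncc([N+](=O)[O-])n1CCSc1nnc(-c2ccc(F)cc2)o1`: 600 nM
- compound 3 `Cc1ncc([N+](=O)[O-])n1CCSc1nnc(-c2ccccc2O)o1`: 19600 nM

Compound 3 sits with compound 1 at the upper end of these numbers, and the gap between them is small: a 2.0-fold higher number from compound 1 to compound 3 (0.29 log units; within the scatter). Compound 2 stands well apart: a 33-fold higher number from compound 2 to compound 3 (1.51 log units; beyond the scatter).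

Compound 4 `Cc1ccc(-c2nnc(SCCn3c([N+](=O)[O-])cnc3C)o2)c(O)c1` is the next case. It carries methyl in place of hydrogen on an aromatic carbon, meta to a hydroxy group and para to a large group. The aryl group thus goes from 2-hydroxyphenyl to 2-hydroxy-4-methylphenyl.

Within the data shown here, no measured pair tests a methyl on this ring, so the evidence is indirect. Among the measured compounds shown here, the closest precedent is the small change on the oxygen: a 2.0-fold higher number from compound 1 to compound 3 (0.29 log units; within the scatter). The large steps, a 17-fold lower number from compound 1 to compound 2 (1.22 log units; beyond the scatter) and a 33-fold higher number from compound 2 to compound 3 (1.51 log units; beyond the scatter), both exchange the 4-fluorophenyl for an aryl group of another pattern, a far bigger edit than the one here. Compound 4 keeps the hydroxy group of compound 3, so no step beyond the scatter is expected in this assay.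

The expected step is a 1.3-fold lower number from compound 3 to compound 4 (0.12 log units; within the scatter). The estimate for compound 4 is 15000 nM, with an expected range of 6000 nM to 35000 nM.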

Compound 4, half-maximal inhibitory concentration: 16600 nM
Compound 4: middle estimate off by 1.1-fold (0.04 log units), on the low side; the range from low to high includes it.
By their numbers in this assay, from the lowest: compound 2; then compounds 1, 4 and 3 (each within the scatter of the next).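

In this assay, among these compounds, methyl in place of hydrogen on this aromatic carbon, meta to the hydroxy group and para to the large group, gives the first direct reading at this position (a 1.2-fold lower number from compound 3 to compound 4 (0.07 log units; within the scatter)), and the step cannot be told from the scatter. The large gap to the 4-fluorophenyl group remains with the added methyl (a 28-fold higher number from compound 2 to compound 4 (1.44 log units; beyond the scatter)), while 2-hydroxy-4-methylphenyl stays within the scatter of 2-methoxyphenyl (a 1.7-fold higher number from compound 1 to compound 4 (0.22 log units; within the scatter)), so compound 2 still stands alone at the low end of the series. Nothing on hand explains either the flat methyl step or the large gap to compound 2.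

Still open is whether the low number of compound 2 goes with the fluorine itself or with the lack of an oxygen substituent on the aryl group, since the compounds shown change both together; a 2-hydroxy-4-fluorophenyl or a plain 4-methylphenyl group would separate the two. An amine or a carboxylic acid on this same aromatic carbon would show whether the flat result extends beyond methyl.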